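Adding a Second Bromine to the Methoxy Analogue

The compounds below may be only part of what the source reports. "The series", "measured", "known", "first", "only" and "open" are said of these compounds alone.

Three compounds have been measured so far in a functional assay on HepG2 cells (Homo sapiens) for cytotoxicity, read by MTT assay, with a stated time of 72 h; a higher number here means a weaker inhibitor, a lower number a stronger inhibitor:

Compound 1 `O=C(N/N=C/c1ccc(O)c(Br)c1)Nc1cc2c(Nc3ccc(F)c(Cl)c3)ncnc2cc1O[C@H]1CCOC1`: 660 nM
Compound 2 `O=C(N/N=C/c1cc(Br)c(O)c(Br)c1)Nc1cc2c(Nc3ccc(F)c(Cl)c3)ncnc2cc1O[C@H]1CCOC1`: 2740 nM
Compound 3 `COc1cc2ncnc(Nc3ccc(F)c(Cl)c3)c2cc1NC(=O)N/N=C/c1ccc(O)c(Br)c1`: 23800 nM

Compound 1 and compound 2 share one core and differ in a single place, (bromo in place of hydrogen on an aromatic carbon). That change produced a 4.2-fold higher number from compound 1 to compound 2 (0.62 log units; beyond the scatter). Compound 3 carries a different core; how it differs from compound 1 is methyl in place of oxolan-3-yl on an oxygen on an aromatic ring, and this exchange gave a 36-fold higher number from compound 1 to compound 3 (1.56 log units; beyond the scatter), leaving compound 3 with the highest number of the three.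

Compound 4 `COc1cc2ncnc(Nc3ccc(F)c(Cl)c3)c2cc1NC(=O)N/N=C/c1cc(Br)c(O)c(Br)c1` has not been measured. It stands to compound 3 as compound 2 stands to compound 1: the difference is bromo in place of hydrogen on an aromatic carbon. The surroundings of the place are described in the same words for both pairs, so this is the same change made a second time, now on the core of compound 3.

Among the measured compounds shown here, with only one earlier example, the expectation rests on that single step. For the measured compounds named here, compound 4 is expected to show a 3.8-fold higher number from compound 3 to compound 4 (0.58 log units; beyond the scatter) in this assay, a step of about the size seen from compound 1 to compound 2, because a 4.2-fold higher number from compound 1 to compound 2 (0.62 log units; beyond the scatter) is the only guide available. The estimate for compound 4 is therefore 90000 nM, with a plausible range from 30000 nM to 250000 nM. Because compound 3 already gave 23800 nM, a number this high may sit near the edge of what the assay can report, so the actual result for compound 4 is awaited.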

Compound 4, half-maximal inhibitory concentration: 36800 nM
For compound 4 the middle estimate is 2.4-fold (0.39 log units) above the measured one; the range from low to high includes it.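

On the core of compound 3, going from 3-bromo-4-hydroxyphenyl to 3,5-dibromo-4-hydroxyphenyl gives a 1.5-fold higher number from compound 3 to compound 4 (0.19 log units; within the scatter), so the step seen on the core of compound 1 does not carry over at the same size: the same change on two cores in this assay, a 4.2-fold higher number (0.62 log units; beyond the scatter) from compound 1 to compound 2 and a 1.5-fold higher number (0.19 log units; within the scatter) from compound 3 to compound 4, 2.7-fold (0.43 log units) apart, beyond the scatter of two such steps

Read the other way, with the second bromine already present, replacing oxolan-3-yl with methyl on the oxygen gives a 13-fold higher number from compound 2 to compound 4 (1.13 log units; beyond the scatter), which is still a large step but a smaller one than the step without that bromine: the same change on two cores in this assay, a 36-fold higher number (1.56 log units; beyond the scatter) from compound 1 to compound 3 and a 13-fold higher number (1.13 log units; beyond the scatter) from compound 2 to compound 4, 2.7-fold (0.43 log units) apart, beyond the scatter of two such steps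

Both comparisons rest on the same four compounds, so they are one observation seen from two sides; it shows that the size of each step depends on the other change, but it does not show why, or how the bromine step would behave on any further core.

The compounds shown leave open whether a chloro group or a methyl group in place of the second bromine would behave as bromo does on these two cores. They also leave open what an ethyl group, or a longer chain ending in an amine, would do on that oxygen in place of methyl or oxolan-3-yl.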